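Benzofuran in Place of Thiophene: Expected Cell Toxicity

This account rests on a few compounds, and the source may have more. Where it says the series, first, only, none or still open, it means among the compounds named here.

compound 1 `COc1ncnc2c1c(-c1cccs1)cn2[C@@H]1O[C@H](CO)[C@@H](O)[C@H]1O` — 43200 nM
compound 2 `COc1nc(N)nc2c1c(-c1cccs1)cn2[C@@H]1O[C@H](CO)[C@@H](O)[C@H]1O` — > 100000 nM
compound 3 `Cc1ncnc2c1c(-c1cccs1)cn2[C@@H]1O[C@H](CO)[C@@H](O)[C@H]1O` — > 100000 nM

Within the data shown here, in an ADME assay on MRC5 cells (Homo sapiens), read by MTT assay, with a stated time of 72 h (on this read-out lower numbers stand for stronger inhibition and higher numbers for weaker inhibition), compound 1 gives 43200 nM, the only true number among the three values. Compound 2 reaches only a limit of the assay, > 100000 nM. Compound 3 likewise reaches only a limit, > 100000 nM. Both measured steps run upward: an at least 2.3-fold higher number from compound 1 to compound 2 (0.36 log units; beyond the scatter) and an at least 2.3-fold higher number from compound 1 to compound 3 (0.36 log units; beyond the scatter), each ending at the limit of > 100000 nM in this assay, at which 2 of the 3 values shown sit.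

Compound 4 `COc1ncnc2c1c(-c1cc3ccccc3o1)cn2[C@@H]1O[C@H](CO)[C@@H](O)[C@H]1O` differs from compound 1 by 1-benzofuran-2-yl in place of thiophen-2-yl on an aromatic carbon. Among the measured compounds shown here, neither measured step touches this part of the core, so no measured step bears on the change, and its size is unknown. Compound 4 is therefore expected to stay within the scatter of compound 1, a 1.2-fold lower number from compound 1 to compound 4 (0.09 log units; within the scatter), with an estimate of 35000 nM ranging from 10000 nM to 100000 nM.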

Compound 4, half-maximal inhibitory concentration: 65600 nM
Compound 4: middle estimate off by 1.9-fold (0.27 log units), on the low side; the range from low to high includes it.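

In this assay, putting 1-benzofuran-2-yl in place of thiophen-2-yl, on an aromatic carbon of a five-membered aromatic ring with 1 nitrogen, gives a 1.5-fold higher number from compound 1 to compound 4 (0.18 log units; within the scatter). Among these compounds, this is the first change at this position, and a group of 9 heavy atoms in place of one of 5 leaves the read-out within the scatter. Both ends of this step are true numbers, so its size can be read in full, whereas each earlier step ends at a limit of the assay: the limit of > 100000 nM in this assay, at which 2 of the 4 values shown sit.

On these data alone, it remains open how a phenyl ring or an amine would read at this position. Also open, as far as these compounds go, is whether the amino and methyl exchanges on the shared core would read the same alongside 1-benzofuran-2-yl.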